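From compound 1 to compound 3: one carboxy group replaced

The compounds below may be only part of what the source reports. "The series", "measured", "known", "first", "only" and "open" are said of these compounds alone.

In a functional assay on DU-145 cells (Homo sapiens) for inhibition, read by trypan blue exclusion, with a stated time of 96 h (a higher number here means a weaker inhibitor of growth, a lower number a stronger inhibitor of growth), compound 1 `O=C(O)c1ccc(/C=C(/SCc2ccc(Cl)cc2)C(=O)c2ccc(C(=O)O)cc2)cc1` gives > 100000 nM as its entry, which is a limit of the assay and not a number. In this assay, among the compounds with values here, compound 2 `O=C(/C(=C\c1ccccc1F)S(=O)(=O)c1ccc(Br)cc1)c1ccc(Cl)cc1` gives 25000 nM as a true number, the only one so far.

Compound 3 `CSc1ccc(/C=C(/SCc2ccc(Cl)cc2)C(=O)c2ccc(C(=O)O)cc2)cc1` keeps the core of compound 1 and differs in one place, methylsulfanyl in place of carboxy on an aromatic carbon with methylsulfanyl in place of carboxy on an aromatic carbon, para to a large group. Within the data shown here, no measured step isolates this change, so any expectation rests on little. It starts from compound 1, whose entry of > 100000 nM leaves room only toward stronger inhibition. Among the measured compounds shown here, the sole numerical anchor is compound 2, at 25000 nM in the same test.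

The expected step of an at least 3.3-fold lower number from compound 1 to compound 3 (0.52 log units; beyond the scatter) points toward stronger growth inhibition and beyond the scatter, although another limit reading remains possible. The estimate for compound 3 is 30000 nM, with an expected range from 6000 nM to 100000 nM.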

Compound 3, concentration for 50% growth inhibition: > 100000 nM
Compound 3 gave a limit, no number; the forecaster's own chance of this, stated with the estimate: 30%; middle value at least 3.3-fold (0.52 log units) from the limit.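

Compound 3, like compound 1, returns a limit of the assay and not a number, so no step can be read between them, because neither entry gives a value to compare: the limit of > 100000 nM in this assay, at which 2 of the 3 values shown sit.

The compounds shown leave open whether methylsulfanyl in place of carboxy on an aromatic carbon changes growth inhibition at all in this assay.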